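Shortening the 3-hydroxypropyl chain to 2-hydroxyethyl

The source may report more compounds than this note shows. Statements on the series, on what has been measured and on what is new or still open speak of the compounds shown alone.

Measured so far in a physicochemical assay for solubility, using the shake flask method, in phosphate buffer, with a stated time of 90 min, at pH 6.8 (a higher number here means a more soluble compound, a lower number a less soluble compound), as the read-out solubility:
Compound 1 `COc1cc(/C=C/C(=O)/C=C(/C=C/c2ccc(O)c(OC)c2)NCCO)ccc1O` gives 8140 nM
Compound 2 `O=C(/C=C(/C=C/c1ccc(O)cc1)NCCCO)/C=C/c1ccc(O)cc1` gives 137000 nM

Compound 2 stands highest of these two numbers, and its gap to compound 1 lies beyond the scatter. Compound 3 `O=C(/C=C(/C=C/c1ccc(O)cc1)NCCO)/C=C/c1ccc(O)cc1` carries hydroxy in place of hydroxymethyl on a saturated chain carbon, two bonds along the chain from an amine nitrogen. Among the measured compounds shown here, no measured pair shows this change alone. In this assay the expected result is a slight fall that stays within the scatter, an estimated 1.5-fold lower number from compound 2 to compound 3 (0.18 log units; within the scatter) as the step. For compound 3 the estimate is 90000 nM with an expected range of 30000 nM to 220000 nM in all.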

Compound 3, solubility: 38700 nM
For compound 3 the middle estimate is 2.3-fold (0.37 log units) above the measured one; the measured number falls inside the stated range.
By their numbers in this assay, from the lowest: compound 1; then compound 3; then compound 2.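

In this assay, the step from 3-hydroxypropyl to 2-hydroxyethyl gives a 3.5-fold lower number from compound 2 to compound 3 (0.55 log units; beyond the scatter), so this position responds to a change in chain length alone, with the core unchanged. The earlier compounds shown here could not show this, as they differ in more than one place. Nothing available accounts for the size of this step.

On these data alone, whether a longer chain, or an amine or carboxylic acid in place of the hydroxy, would move the number further remains open. So does whether the same shortening would have a similar effect on the core of compound 1.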